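Swapping the amide tail for a dichlorophenyl urea

This account rests on a few compounds, and the source may have more. Where it says the series, first, only, none or still open, it means among the compounds named here.

Going by the values given here, compound 1 `COc1cc(-c2nn(-c3cccc(NC(=O)c4cccc(C(F)(F)F)c4)c3)cc2-c2ccncc2)ccc1Cl` is one of three compounds measured in a functional assay on UO-31 cells (Homo sapiens) for inhibition, read by sulforhodamine B assay, with a stated time of 48 h; a higher number here means a weaker inhibitor of growth, a lower number a stronger inhibitor of growth; compound 1 gives 968 nM. Compound 2 `O=C(Nc1cccc(-n2cc(-c3ccncc3)c(-c3ccc(Cl)c(O)c3)n2)c1)Nc1cccc(C(F)(F)F)c1` gives 1860 nM in this assay, and compound 3 `O=C(Nc1cccc(-n2cc(-c3ccncc3)c(-c3ccc(Cl)c(O)c3)n2)c1)Nc1ccc(Cl)c(C(F)(F)F)c1` gives 777 nM. Compound 1 therefore stands second highest of the three, within the scatter of both neighbours. Among the compounds with values here, the one clean step in this set is a 2.4-fold lower number from compound 2 to compound 3 (0.38 log units; beyond the scatter), where the change is chloro in place of hydrogen on an aromatic carbon.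

Compound 4 `COc1cc(-c2nn(-c3cccc(NC(=O)Nc4ccc(Cl)c(Cl)c4)c3)cc2-c2ccncc2)ccc1Cl` differs from compound 1 in one place: (3,4-dichlorophenyl)amino in place of 3-(trifluoromethyl)phenyl on a carbonyl carbon. This change has two parts at once, an amide becoming a urea and the aromatic ring gaining chlorines while losing the trifluoromethyl. Within the data shown here, no measured pair isolates the amide-to-urea part; compound 1 and compound 2 differ in a second place as well, so their two values can only be read together. The chloro step between compound 2 and compound 3 is the one that bears on the ring part, and it was modest. A modest move to a lower number is therefore expected for compound 4, a 1.6-fold lower number from compound 1 to compound 4 (0.21 log units; within the scatter), with compound 4 estimated at 600 nM and a likely range from 250 nM to 1500 nM.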

Compound 4, concentration for 50% growth inhibition: 845 nM
Beside the measured number, compound 4's estimate is 1.4-fold (0.15 log units) below it; the range from low to high includes it.
By their numbers in this assay, from the lowest: compounds 3, 4, 1 and 2 (each within the scatter of the next, the first and the last beyond it).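

Exchanging the 3-(trifluoromethyl)phenyl on the carbonyl carbon for (3,4-dichlorophenyl)amino gives a 1.1-fold lower number from compound 1 to compound 4 (0.06 log units; within the scatter) in this assay. The earlier compounds shown here showed a readable step only for a single added chloro, whereas this larger change, which swaps the fluorines for chlorines and brings in a nitrogen with a hydrogen-bond donor, leaves the two numbers within the scatter of each other. No measurement is available that would explain this result.

On these data alone, since the amide-to-urea change and the change on the ring occur together, it remains open whether each has little effect or whether the two cancel. The compounds shown also leave open how the tail would respond to a much different group on the ring, such as a carboxylic acid or a morpholine.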